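The compounds below may be only part of what the source reports. "The series", "measured", "known", "first", "only" and "open" are said of these compounds alone.

Working notes. In a functional assay on the whole organism (strain Jcl:SD) for inhibition, with Rattus norvegicus as the target, with stated times of 3 min and 3 h, at a dose of 1 mg/kg by the intravenous route (on this read-out lower numbers stand for less inhibition and higher numbers for more inhibition at the one dose given (going by the name of the read-out)), compound 1 `CNCc1cc(-c2cccnc2Cl)n(S(=O)(=O)c2cccnc2)c1` gives 92%, compound 2 `CNCc1cc(-c2cccnc2C#N)n(S(=O)(=O)c2cccnc2)c1` gives 48% and compound 3 `CNCc1cc(-c2cccnc2C)n(S(=O)(=O)c2cccnc2)c1` gives -41%. Compound 3 stands lowest of the three; compound 2 is nearest to it, and the steps of a number 133 percentage points lower from compound 1 to compound 3 (beyond the scatter) and a number 89 percentage points lower from compound 2 to compound 3 (beyond the scatter) are both large, as is a number 44 percentage points lower from compound 1 to compound 2 (beyond the scatter). Compound 4 `CNCc1cc(-c2cnccc2C)n(S(=O)(=O)c2cccnc2)c1` differs from compound 3 by 4-methylpyridin-3-yl in place of 2-methylpyridin-3-yl on an aromatic carbon. Going by the values given here, no measured step moves the methyl in this way; the three steps all exchange the group on the same aromatic carbon, and each shifted this assay strongly. The direction for compound 4 is therefore open, and a step of either sign beyond the scatter is possible. On balance compound 4 is expected near 20%, between -40% and 75%, meaning an estimated step of a number 61 percentage points higher from compound 3 to compound 4 (beyond the scatter).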

Compound 4, a percentage reported as inhibition, in the whole organism at one dose (the size of the read-out at that dose, not a potency): -54%
The estimate for compound 4 lay 74 percentage points above the measured number; the whole stated range lies above it.
By their numbers in this assay, from the lowest: compound 4; then compound 3; then compound 2; then compound 1.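

Moving the methyl from 2-methylpyridin-3-yl to 4-methylpyridin-3-yl gives (a number 13 percentage points lower from compound 3 to compound 4 (beyond the scatter)) in (this assay), a modest step beyond the scatter, so both methyl compounds stay at the low end of the series. Compound 4 also lies far from the chloro and cyano compounds, with (a number 102 percentage points lower from compound 2 to compound 4 (beyond the scatter)) and (a number 146 percentage points lower from compound 1 to compound 4 (beyond the scatter)) as the steps. No measurement available here explains these differences. On these data alone, it remains open whether an amine or a methoxy group in place of the chloro of compound 1 would retain a high number, and whether a chloro group in place of the methyl of compound 4 would raise it.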